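One Ring Swap on a Weak Colon-Cancer Inhibitor

This account rests on a few compounds, and the source may have more. Where it says the series, first, only, none or still open, it means among the compounds named here.

Compound 1 `O=C1O/C(=C\Cn2ncc(=O)[nH]c2=O)C(OCc2ccccc2)=C1OCc1ccccc1` carries a six-membered ring with three hetero atoms at the end of its side chain. Among the compounds with values here, in a functional assay on SW-620 cells (Homo sapiens) for inhibition, read by MTT assay, with a stated time of 72 h (a higher number here means a weaker inhibitor, a lower number a stronger inhibitor), compound 1 gives 36500 nM, the only plain number among the two values shown. Compound 2 `NC1(CCn2ccc(=O)[nH]c2=O)OC(=O)C(OCc2ccccc2)=C1OCc1ccccc1` gives only > 100000 nM, which is a limit of the assay and not a number (the limit of > 100000 nM in this assay, at which 1 of the 2 values shown sits). Compound 3 `O=C1O/C(=C\Cn2c(=O)[nH]c(=O)[nH]c2=O)C(OCc2ccccc2)=C1OCc1ccccc1` differs from compound 1 by a group of 9 heavy atoms (3 carbon, 3 nitrogen, 3 oxygen; one six-membered aromatic ring with 3 hetero atoms) in place of a group of 8 heavy atoms (3 carbon, 3 nitrogen, 2 oxygen; one six-membered aromatic ring with 3 hetero atoms), on a saturated chain carbon bound to a double-bonded chain carbon. Within the data shown here, no measured step covers this change, so no direction can be read from the data, and a step within the usual scatter seems most likely. Compound 3 is therefore estimated at 40000 nM, between 15000 nM and 100000 nM, a shift a 1.1-fold higher number from compound 1 to compound 3 (0.04 log units; within the scatter) expected to stay small.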

Compound 3, half-maximal inhibitory concentration: > 100000 nM
Compound 3: a limit, no number (the forecaster's own chance of this, stated with the estimate: 30%); middle value at least 2.5-fold (0.39 log units) from the limit.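

Swapping one ring for the other, on a saturated chain carbon bound to a double-bonded chain carbon, is not a neutral change in this assay: the data show an at least 2.7-fold higher number from compound 1 to compound 3 (0.43 log units; beyond the scatter), a loss the earlier compounds could not reveal. Going by these compounds, compound 3 gives a limit of the assay and not a number, so the full size of this step stays unknown: the limit of > 100000 nM in this assay, at which 2 of the 3 values shown sit.

The compounds shown leave open whether a simpler group at this place, such as an amine or a carboxylic acid, would give a lower number than compound 1.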